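The compounds below may be only part of what the source reports. "The series", "measured", "known", "first", "only" and "open" are said of these compounds alone.

In a functional assay on CHO cells for antagonist activity at metabotropic glutamate receptor 5 (Homo sapiens), read by calcium flux (on this read-out higher numbers stand for weaker inhibition and lower numbers for stronger inhibition), three compounds have been measured: compound 1 `Cc1c(C(C)OC(=O)Nc2ccccc2)oc2nc(-c3ccc(F)cc3)nn12` gives 10 nM, compound 2 `Cc1c(C(C)OC(=O)Nc2ccccc2)sc2nncn12` gives 126 nM, and compound 3 `Cc1c(C(C)OC(=O)Nc2cccc(F)c2)sc2nncn12` gives 63.1 nM.

Compound 3 stands second highest of these three numbers. Its nearest neighbour is compound 2, and the step of a 2.0-fold lower number from compound 2 to compound 3 (0.30 log units; within the scatter) lies within the scatter; compound 1 sits furthest away, with a lower number beyond the scatter.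

Compound 4 `Cc1c([C@@H](C)OC(=O)Nc2cccc(F)c2)sc2nncn12` keeps every atom and bond of compound 3: the two compounds have the same atoms and bonds; at least one stereo element is drawn with a configuration in one of them and without one in the other: 1 of 1 stereo elements differ; a stereocentre at a saturated chain carbon is drawn without a configuration in compound 3 and R in compound 4. Among the measured compounds shown here, none of the measured steps concerns a drawn configuration, so no direct guide exists; the single measured step, a 2.0-fold lower number from compound 2 to compound 3 (0.30 log units; within the scatter), concerns a fluoro substituent only. A modest shift, in either direction, is expected: a 1.6-fold lower number from compound 3 to compound 4 (0.20 log units; within the scatter). Compound 4 is therefore estimated at 40 nM, ranging from 10 nM to 250 nM.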

Compound 4, half-maximal inhibitory concentration: 39.8 nM
Compound 4: the middle estimate sits 1.0-fold (0.00 log units) above what was measured; the measured number falls inside the stated range.
By their numbers in this assay, from the lowest: compound 1; then compounds 4, 3 and 2 (each within the scatter of the next, the first and the last beyond it).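

Among the compounds shown here, the first measured step to touch a drawn configuration is a 1.6-fold lower number from compound 3 to compound 4 (0.20 log units; within the scatter) and so does not separate the two compounds in this assay. At this saturated chain carbon, drawing the R configuration therefore leaves the number indistinguishable from that of the undefined drawing. Only one structural difference stands behind this comparison: the fact that one of compounds 3 and 4 is drawn with a defined configuration and the other without, at the place where they differ.

From the compounds shown here alone, how the S configuration at this carbon would read remains open. So does whether an ethyl group in place of the methyl group on this carbon would keep the number within the same range.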